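Swapping the Aryl Ether Substituent on a Bicyclic Amine

This account rests on a few compounds, and the source may have more. Where it says the series, first, only, none or still open, it means among the compounds named here.

Compound 1 `C1=C(c2cncnc2)CC2CNCC1C2` gives 58 nM in an in vitro assay on SH-SY5Y cells for displacement of a labelled ligand from Neuronal acetylcholine receptor; alpha3/beta4 (Homo sapiens); on this read-out higher numbers stand for weaker inhibition and lower numbers for stronger inhibition.
Compound 2 `Clc1ccc(Oc2cncc(C3=CC4CNCC(C3)C4)c2)cc1` gives 40 nM in this assay.
Compound 3 `COc1ccc(C2=CC3CC(C2)CN(C)C3)cn1` reaches only an assay limit of > 10000 nM in this assay and so has no number.

Within the data shown here, of the two numbers known, compound 2 holds the lower one, but its gap to compound 1 lies within the scatter, so neither compound can be called stronger than the other. Compound 4 `COc1cccc(Oc2cncc(C3=CC4CNCC(C3)C4)c2)c1` is not yet measured. It differs from compound 2 in one place: 3-methoxyphenyl in place of 4-chlorophenyl on an oxygen on an aromatic ring. Among the measured compounds shown here, no measured pair shows what such a swap does here, so the expectation rests on compound 2 alone. The step of a 1.5-fold higher number from compound 2 to compound 4 (0.18 log units; within the scatter) is expected to stay within the scatter, with no clear direction. Compound 4 is therefore estimated at 60 nM with a range from 20 nM to 200 nM.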

Compound 4, inhibition constant: 15 nM
For compound 4 the middle estimate is 4.0-fold (0.60 log units) above the measured one; measured number outside the range, below it.
By their numbers in this assay, from the lowest: compound 4; then compounds 2 and 1 (each within the scatter of the next). At a limit, above all of these: compound 3.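

The ring on this ether oxygen is a place where a swap can be read: in this assay, 3-methoxyphenyl in place of 4-chlorophenyl gives a 2.7-fold lower number from compound 2 to compound 4 (0.43 log units; beyond the scatter) as a modest change. Since a lower number stands for stronger inhibition, the swap gains inhibition rather than losing it. Among these compounds, it is the first measured step at this place, and it shows that the 4-chlorophenyl group is not required for inhibition here.

Nothing shown accounts for why this swap lowers the number. Also open, as far as these compounds go, is what a ring carrying an amine or a carboxylic acid, or a plain methyl group, would do on the same oxygen.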